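The compounds below may be only part of what the source reports. "The series", "measured", "known", "first", "only" and "open" are said of these compounds alone.

Compound 1 `CC(=O)C1=C(C)NC(=O)NC1c1ccco1`: 38%
Compound 2 `CC1=C(C(N)=O)C(c2ccco2)NC(=O)N1`: 2%

In an assay on HEK293 cells for displacement of a labelled ligand from adenosine receptor A2b (Homo sapiens), with a stated time of 30 min, tested at 10 uM (a higher number here means more inhibition at the concentration tested (going by the name of the read-out), a lower number less inhibition), compound 2 gives 2%, the lowest of the two numbers, while compound 1 gives 38%. Compound 3 `CC1=C(C(=O)OC(C)(C)C)C(c2ccco2)NC(=O)N1` differs from compound 2 by tert-butoxy in place of amino on a carbonyl carbon. For the measured compounds named here, the one measured step that bears on this, a number 36 percentage points lower from compound 1 to compound 2 (beyond the scatter), came with the arrival of that same amino group at the carbonyl carbon. Going by the values given here, its removal in compound 3 is therefore expected to bring a step of a number 23 percentage points higher from compound 2 to compound 3 (beyond the scatter) upward, though no measured step directly covers a tert-butoxy group. Compound 3 is estimated at 25%, with a range from 5% to 50%.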

Compound 3, a percentage reported as inhibition, at one concentration (the size of the read-out at that concentration, not a potency): 44%
Estimate against measurement, compound 3: 19 percentage points below, within the range that was stated.
By their numbers in this assay, from the lowest: compound 2; then compounds 1 and 3 (each within the scatter of the next).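

On this carbonyl carbon, the low number of compound 2 does not extend to every replacement: tert-butoxy in place of amino gives a number 42 percentage points higher from compound 2 to compound 3 (beyond the scatter). Tert-butoxy in place of methyl gives a number 6 percentage points higher from compound 1 to compound 3 (within the scatter), so among these three compounds only the amino compound stands apart. Nothing measured here explains this difference. On these data alone, whether a methoxy group or a carboxylic acid at this carbon would group with compound 2 or with compounds 1 and 3 stays open. A methylamino group would show whether the low number extends beyond amino itself.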